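This account rests on a few compounds, and the source may have more. Where it says the series, first, only, none or still open, it means among the compounds named here.

Working notes on the series. Compound 1 `O=c1c2cnn(-c3ccc(F)cc3)c2ncn1CC1(O)CCN(Cc2ccc(Cl)cc2)CC1` gives 8000 nM in an assay on Sf21 cells for inhibition of ubiquitin carboxyl-terminal hydrolase 7 (Homo sapiens), read by spectrophotometry, with stated times of 30 min and 2 h; a higher number here means a weaker inhibitor, a lower number a stronger inhibitor. Among the compounds with values here, compound 2 `O=c1c2cnn(-c3ccc(F)cc3)c2ncn1CC1(O)CCN(Cc2ccc(F)cc2Cl)CC1` gives 1600 nM in this assay and so holds the lowest of the two numbers so far; the nearest is compound 1, reached by the step of a 5.0-fold lower number from compound 1 to compound 2 (0.70 log units; beyond the scatter), a modest change that already carried two alterations on the benzyl ring at once.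

The next compound, compound 3 `O=c1c2cnn(-c3ccc(F)cc3)c2ncn1CC1(O)CCN(Cc2ccc(Cl)cc2Cl)CC1`, differs from compound 2 by chloro in place of fluoro on an aromatic carbon, placed para to a large group and meta to a chloro group. Within the data shown here, no measured pair isolates this exchange: the only step known, from compound 1 to compound 2, mixes the para-position swap with the arrival of the second chloro, so its size cannot be assigned to either part. A halogen-for-halogen exchange of this kind is expected to move the number little, most likely within or just beyond the scatter, with a slight lean toward a lower value. Compound 3 is therefore estimated at 1200 nM, range 500 nM to 3500 nM, a step of a 1.3-fold lower number from compound 2 to compound 3 (0.12 log units; within the scatter).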

Compound 3, half-maximal inhibitory concentration: 3300 nM
Estimate against measurement, compound 3: 2.8-fold (0.44 log units) below, and the stated range covers the measured number.
By their numbers in this assay, from the lowest: compound 2; then compound 3; then compound 1.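

In this assay, chloro in place of fluoro, para to a large group and meta to a chloro group, gives a 2.1-fold higher number from compound 2 to compound 3 (0.31 log units; beyond the scatter), so this position distinguishes between the two halogens, and the 2-chloro-4-fluorobenzyl group gives the lower number of this pair. Chloro in place of hydrogen on an aromatic carbon, read on its own, gives a 2.4-fold lower number from compound 1 to compound 3 (0.38 log units; beyond the scatter), which separates the mixed a 5.0-fold lower number from compound 1 to compound 2 (0.70 log units; beyond the scatter) into two single changes: the 2,4-dichlorobenzyl group of compound 3 already lowers the number relative to compound 1, and fluoro in place of chloro lowers it further in compound 2. The data at hand offer no explanation for the direction of either change.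

Still open, going by these compounds, is how this position responds beyond the two halogens, for instance to bromo, methoxy or a nitrile in place of fluoro. Within the data shown here, also open is whether the preference for fluoro over chloro holds without the second chloro on the ring, as the only pair that reads this exchange has that chloro present.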